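The source may report more compounds than this note shows. Statements on the series, on what has been measured and on what is new or still open speak of the compounds shown alone.

Values in a functional assay on HL-60 cells (Homo sapiens) for antiproliferative activity, read by MTT assay, with a stated time of 48 h (on this read-out lower numbers stand for stronger inhibition and higher numbers for weaker inhibition), so far
- compound 1 `CCN(CC)C/C1=C/C[C@](C)(CCC=C(C)C)/C=C/[C@@H](OC(=O)C=C(C)C)[C@](C)(O)/C=C/C1=O` gives 140 nM
- compound 2 `CC(C)=CCC[C@]1(C)/C=C/[C@@H](OC(=O)C(C)C)[C@](C)(O)/C=C/C(=O)/C(CO)=C\C1` gives 4000 nM

Compound 2 with 4000 nM holds the higher number of the two, and its gap to compound 1 lies beyond the scatter. These two compounds differ in more than one place, so that gap cannot be assigned to any single change.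

Still unmeasured in this assay is compound 3 `COCO[C@@H]1/C=C/[C@@](C)(CCC=C(C)C)C/C=C(/CO)C(=O)/C=C/[C@@]1(C)O` which departs from compound 2 by one change: methoxymethyl in place of isopropylcarbonyl on an oxygen on a saturated carbon with methoxymethyl in place of isopropylcarbonyl on an oxygen on a saturated carbon. Among the compounds with values here, neither measured compound carries methoxymethyl at that place, so no measured pair shows the size of this change. A small rise in the number is expected, and the estimated 1.5-fold higher number from compound 2 to compound 3 (0.18 log units; within the scatter) may well stay within the scatter. Compound 1 with 140 nM also differs from compound 2 elsewhere, so it offers no firm guide and the range is kept wide. For compound 3 the estimated value is 6000 nM with an expected range from 2000 nM to 20000 nM in repeat measurements.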

Compound 3, half-maximal inhibitory concentration: > 40000 nM
Compound 3 gave a limit, no number (the forecaster's own chance of this, stated with the estimate: 10%); middle value at least 6.6-fold (0.82 log units) away from the limit.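

In this assay compound 3 gives > 40000 nM, which is a limit of the assay and not a number: the limit of > 40000 nM in this assay, at which 1 of the 3 values shown sits. Within the data shown here, the change to methoxymethyl in place of isopropylcarbonyl on an oxygen on a saturated carbon is the first single change that can be read, and it amounts to an at least 10-fold higher number from compound 2 to compound 3 (1.00 log units; beyond the scatter). As far as these compounds go, the group on this oxygen therefore matters for the read-out in this pair, a point that the gap between compounds 1 and 2 could not show, and the full size of the step remains unknown since only its lower bound is available.

Open, from the compounds shown here alone, is whether the step reflects the loss of isopropylcarbonyl or the arrival of methoxymethyl, a question that a free hydroxyl, an acetyl group or a longer acyl chain such as hexanoyl on the same oxygen would help to settle. Also open, going by these compounds, is whether the same change has a step of similar size on the core of compound 1, which carries a diethylaminomethyl group in place of the hydroxymethyl group of compound 2.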